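The source may hold more compounds than are shown below. What is called first, only, known or untested is meant among the compounds shown, and "the series" means these compounds.

Measured in a functional assay on RKOp27 cells (Homo sapiens) for cytotoxicity, read by MTT assay, with a stated time of 3 days; on this read-out higher numbers stand for weaker inhibition and lower numbers for stronger inhibition:
- compound 1 `N#Cc1c(Nc2ccccc2)nc(SCc2nc3ccccc3[nH]2)nc1-c1ccccc1` gives 4.9 nM
- compound 2 `CNc1nc(SCc2nc3ccccc3[nH]2)nc(-c2ccccc2)c1C#N` gives 3.7 nM
- compound 3 `N#Cc1c(Nc2ccccn2)nc(SCc2nc3ccccc3[nH]2)nc1-c1ccccc1` gives 3.8 nM

Compound 3 at 3.8 nM lies within the scatter of both other compounds, so the three values carry no order. Compound 4 `N#Cc1c(NNC(N)=S)nc(SCc2nc3ccccc3[nH]2)nc1-c1ccccc1` changes the group on a nitrogen on an aromatic ring (a group of 4 heavy atoms (1 carbon, 2 nitrogen, 1 sulfur; no ring) in place of a group of 6 heavy atoms (5 carbon, 1 nitrogen; one six-membered aromatic ring with 1 hetero atom), on a nitrogen on an aromatic ring). Three measured steps at that nitrogen bear on this change (a 1.3-fold lower number from compound 1 to compound 2 (0.12 log units; within the scatter) and a 1.3-fold lower number from compound 1 to compound 3 (0.11 log units; within the scatter) and a 1.0-fold higher number from compound 2 to compound 3 (0.01 log units; within the scatter)), and each stayed within the scatter. None of the groups in those steps carries sulfur, so the range is kept wide. The expected step in this assay does not go beyond the scatter (a 1.3-fold higher number from compound 3 to compound 4 (0.12 log units; within the scatter)). The estimate for compound 4 is 5 nM (expected range 1.5 nM to 20 nM).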

Compound 4, half-maximal inhibitory concentration: 3.2 nM
Compound 4: the middle estimate sits 1.6-fold (0.19 log units) above what was measured, and the stated range covers the measured number.
By their numbers in this assay, from the lowest: compounds 4, 2, 3 and 1 (each within the scatter of the next).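

In this assay, for the compounds shown here, a group with sulfur and no ring on this nitrogen also stays within the scatter of the earlier compounds (a 1.2-fold lower number from compound 3 to compound 4 (0.07 log units; within the scatter); a 1.2-fold lower number from compound 2 to compound 4 (0.06 log units; within the scatter); a 1.5-fold lower number from compound 1 to compound 4 (0.19 log units; within the scatter)). The range of groups on this nitrogen with no step beyond the scatter therefore now extends from methyl, phenyl and pyridin-2-yl to one with sulfur. No measurement on hand explains this flat response.

On these data alone, whether a carboxylic acid or a longer alkyl chain on this nitrogen would give a step beyond the scatter remains open.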